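From 3-bromophenyl to 3-methylphenyl in a small series

The source may hold more compounds than are shown below. What is called first, only, known or untested is meant among the compounds shown, and "the series" means these compounds.

In a functional assay on PANC-1 cells (Homo sapiens) for inhibition, read by MTT assay, with a stated time of 24 h (a higher number here means a weaker inhibitor, a lower number a stronger inhibitor), compound 1 (`CC1(C)[C@H]2CC[C@]1(C)N(Cc1cn(-c3ccccc3C#N)nn1)C(=O)C2`) gives 240 nM and compound 2 (`CC1(C)[C@H]2CC[C@]1(C)N(Cc1cn(-c3cccc(Cl)c3)nn1)C(=O)C2`) gives 260 nM while compound 3 (`CC1(C)[C@H]2CC[C@]1(C)N(Cc1cn(-c3cccc(Br)c3)nn1)C(=O)C2`) gives 90 nM as the lowest of the three numbers. Compound 4 (`Cc1cccc(-n2cc(CN3C(=O)C[C@@H]4CC[C@@]3(C)C4(C)C)nn2)c1`) has methyl in place of bromo on an aromatic carbon. Among the compounds with values here, no measured compound carries methyl, so the nearest guide is bromo in place of chloro, which gave a 2.9-fold lower number from compound 2 to compound 3 (0.46 log units; beyond the scatter) and is matched in size by a 2.7-fold lower number from compound 1 to compound 3 (0.43 log units; beyond the scatter) for the other route to bromo. In this assay a modest move to a higher number is therefore expected, estimated as a 2.2-fold higher number from compound 3 to compound 4 (0.35 log units; beyond the scatter) and similar in size to those steps. Compound 4 is estimated at 200 nM (expected range 80 nM to 500 nM).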

Compound 4, half-maximal inhibitory concentration: 240 nM
For compound 4 the middle estimate is 1.2-fold (0.08 log units) below the measured one; the range from low to high includes it.
By their numbers in this assay, from the lowest: compound 3; then compounds 1, 4 and 2 (each within the scatter of the next).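

In this assay, methyl in place of bromo on an aromatic carbon returns the number to the level of the other compounds (a 2.7-fold higher number from compound 3 to compound 4 (0.43 log units; beyond the scatter)), so compound 3 alone stands apart among these groups. Methyl and chloro cannot be told apart (a 1.1-fold lower number from compound 2 to compound 4 (0.03 log units; within the scatter)), nor can 3-methylphenyl and 2-cyanophenyl (no change at the digits printed from compound 1 to compound 4 (within the scatter)). Nothing measured here accounts for the bromo result.

The compounds shown leave open whether iodo or methoxy on this aromatic carbon would read like bromo or like methyl and chloro.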